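Moving a Sulfamoyl Group Around the Phenyl Ring

This account rests on a few compounds, and the source may have more. Where it says the series, first, only, none or still open, it means among the compounds named here.

Compound 3 `N#CC1=C(N)Oc2c(c3nc4ccccc4nc3c3ccccc23)C12C(=O)N(Cc1cnnn1-c1ccc(S(N)(=O)=O)cc1)c1ccccc12` sits at the top of the range seen here. In a functional assay on MCF7 cells (Homo sapiens) for antiproliferative activity, read by MTT assay, with a stated time of 48 h (on this read-out lower numbers stand for stronger inhibition and higher numbers for weaker inhibition), compound 3 gives > 50000 nM, which is a limit of the assay and not a number. Compound 1 `N#CC1=C(N)Oc2c(c3nc4ccccc4nc3c3ccccc23)C12C(=O)N(Cc1cnnn1-c1cccc(Cl)c1)c1ccccc12`, with a 3-chlorophenyl on the same aromatic nitrogen, gives in this assay 43600 nM. Compound 2 `N#CC1=C(N)Oc2c(c3nc4ccccc4nc3c3ccccc23)C12C(=O)N(Cc1cnnn1-c1ccc([N+](=O)[O-])cc1)c1ccccc12` gives in this assay > 50000 nM, again a limit of the assay. The step of an at least 1.1-fold higher number from compound 1 to compound 3 (0.05 log units; that floor lies within the scatter) and the step of an at least 1.1-fold higher number from compound 1 to compound 2 (0.05 log units; that floor lies within the scatter) both rest on floors that lie within the usual scatter, and the step that the two limits leave unreadable from compound 2 to compound 3 cannot be read at all, because the limit of > 50000 nM in this assay, at which 2 of the 3 values shown sit, holds both ends of it.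

Compound 4 `N#CC1=C(N)Oc2c(c3nc4ccccc4nc3c3ccccc23)C12C(=O)N(Cc1cnnn1-c1cccc(S(N)(=O)=O)c1)c1ccccc12` differs from compound 3 only in the position of the sulfamoyl group: 3-sulfamoylphenyl in place of 4-sulfamoylphenyl on an aromatic nitrogen. Among the compounds with values here, none of the measured steps moves a group from one position on the phenyl ring to another, so the only guidance is that every phenyl variant so far sits at or close to the limit. The step that the limit leaves unreadable from compound 3 to compound 4 is therefore expected to be none beyond the scatter. Compound 4 is expected to give in this assay 55000 nM, with a range from 30000 nM to 120000 nM, and most likely only a limit will be reported.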

Compound 4, half-maximal inhibitory concentration: 42500 nM
Beside the measured number, compound 4's estimate is 1.3-fold (0.11 log units) above it; the range from low to high includes it.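

Moving the sulfamoyl group turns a limit into a number in this assay, and the change reads as an at least 1.1-fold lower number from compound 3 to compound 4 (0.07 log units; that floor lies within the scatter). Replacing 4-nitrophenyl with 3-sulfamoylphenyl reads as an at least 1.1-fold lower number from compound 2 to compound 4 (0.07 log units; that floor lies within the scatter), and neither step can be told apart from the scatter or given a true size, because each starts from a limit: the limit of > 50000 nM in this assay, at which 2 of the 4 values shown sit. Against the 3-chlorophenyl of compound 1, the 3-sulfamoylphenyl reads as a 1.0-fold lower number from compound 1 to compound 4 (0.01 log units; within the scatter), so the two groups cannot be told apart here; among these four compounds, the 3-chlorophenyl and 3-sulfamoylphenyl compounds give numbers while the 4-nitrophenyl and 4-sulfamoylphenyl compounds give limits, a pattern that goes no further than these four and has no exception among them.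

The compounds shown leave open whether any change on this phenyl ring can move the number in this assay beyond the scatter from compound 1 and compound 4. As far as these compounds go, it also remains open whether an amine or a carboxylic acid in place of the sulfamoyl group, or a longer chain in place of the phenyl ring on the aromatic nitrogen, would do so.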